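Methyl for chloro on the 2-chlorophenyl ring

The source may hold more compounds than are shown below. What is called first, only, known or untested is meant among the compounds shown, and "the series" means these compounds.

Among the compounds with values here, compound 2 `Cc1ccccc1C(=O)Nc1sc2c(c1C(N)=O)CCN(C(=S)Nc1ccccc1Cl)C2` gives 11000 nM in a functional assay on MKN-74 cells (Homo sapiens) for antiproliferative activity, with a stated time of 24 h (a lower number here means a stronger inhibitor, a higher number a weaker inhibitor), the lowest of the three numbers so far, though compound 1 `NC(=O)c1c(NC(=O)c2ccccc2)sc2c1CCN(C(=S)Nc1ccccc1Cl)C2` with 11800 nM sits within the scatter of it, as a 1.1-fold lower number from compound 1 to compound 2 (0.03 log units; within the scatter) shows. Compound 3 `NC(=O)c1c(NC(=O)c2ccncn2)sc2c1CCN(C(=S)Nc1ccccc1Cl)C2` gives 28400 nM, and the steps of a 2.4-fold higher number from compound 1 to compound 3 (0.38 log units; beyond the scatter) and a 2.6-fold higher number from compound 2 to compound 3 (0.41 log units; beyond the scatter) are modest. Compound 4 `Cc1ccccc1NC(=S)N1CCc2c(sc(NC(=O)c3ccccc3C)c2C(N)=O)C1` differs from compound 2 by methyl in place of chloro on an aromatic carbon. Within the data shown here, none of the measured steps touches this ring; the only small one-group swap seen, a 1.1-fold lower number from compound 1 to compound 2 (0.03 log units; within the scatter), stayed within the scatter, and nothing shows how exchanging chloro for methyl acts here. For compound 4 a step of no real size is therefore expected, a 1.1-fold higher number from compound 2 to compound 4 (0.04 log units; within the scatter). Compound 4 is estimated at 12000 nM, within a range of 5000 nM to 30000 nM.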

Compound 4, half-maximal inhibitory concentration: > 50000 nM
Compound 4: a limit, no number; the forecaster's own chance of this, stated with the estimate: 10%; middle value at least 4.1-fold (0.61 log units) away from the limit.
By their numbers in this assay, from the lowest: compounds 2 and 1 (each within the scatter of the next); then compound 3. At a limit, above all of these: compound 4.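

Within the data shown here, the earlier compounds changed only the group on the carbonyl carbon, so this is the first view of the ring that carries the chloro, and here one heavy atom exchanged gives an at least 4.5-fold higher number from compound 2 to compound 4 (0.65 log units; beyond the scatter) in this assay. Compound 4 stands at a limit and not at a number: the limit of > 50000 nM in this assay, at which 1 of the 4 values shown sits. This single swap reaches further than the earlier methyl for hydrogen, a 1.1-fold lower number from compound 1 to compound 2 (0.03 log units; within the scatter).

Among the compounds shown, this ring carries only chloro or methyl, and how fluoro, methoxy or an amine there would fare stays open. Whether the step holds with phenyl or pyrimidin-4-yl on the carbonyl carbon is open too.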